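A few compounds are considered here, and "the series" means these few. Any claim that something is new, unique, unknown or untested is made for them only; others in the source may bear on it.

Measured in an ADME assay on the whole organism (Rattus norvegicus, strain Sprague-Dawley) for pharmacokinetics, using cassette dosing, at a dose of 0.5 mg/kg by the intravenous route; a higher number here means faster removal of the compound, a lower number slower removal:

compound 1 `O=C(c1cc(-c2ccc(=O)[nH]c2)on1)N1CCC(Cc2ccc(F)cc2)CC1`: 19.7 mL/min/kg
compound 2 `O=C(c1cc(-c2ccc(=O)[nH]c2)on1)N1CCC(Cc2ccc(Cl)cc2)CC1`: 5.4 mL/min/kg
compound 3 `C[C@@H]1CN(c2ccc(F)c(F)c2)CCN1C(=O)C(=O)Nc1ccc2[nH]c(=O)oc2c1`: 5.6 mL/min/kg

Compound 4 `C[C@@H]1CN(c2ccc(Cl)c(F)c2)CCN1C(=O)C(=O)Nc1ccc2[nH]c(=O)oc2c1` has not yet been measured in this assay.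

Among the measured compounds shown here, the one step available within a single core is chloro in place of fluoro on an aromatic carbon, which gave a 3.6-fold lower number from compound 1 to compound 2 (0.56 log units; beyond the scatter). Compound 3 and compound 2 sit within the scatter of each other in this assay. The difference between the core of compound 1 and the core of compound 3 is not broken down here.

The change from compound 3 to compound 4 is chloro in place of fluoro on an aromatic carbon. It is the same kind of change as from compound 1 to compound 2, not the same: in compound 4 the altered carbon is ortho to a fluoro group, which the earlier pair lacks, and the two cores differ as well. For the measured compounds named here, a step of the same direction is expected, smaller than the earlier one because of a 3.6-fold lower number from compound 1 to compound 2 (0.56 log units; beyond the scatter) being the only guide on a different core: the expected step is a 1.9-fold lower number from compound 3 to compound 4 (0.27 log units; within the scatter). Compound 4 is estimated at 3 mL/min/kg, with a likely range from 1.2 mL/min/kg to 7.5 mL/min/kg.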

Compound 4, clearance: 1.37 mL/min/kg
The estimate for compound 4 lay 2.2-fold (0.34 log units) above the measured number; measured number inside the range.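

In this assay, chloro in place of fluoro on an aromatic carbon, here taking 3,4-difluorophenyl to 4-chloro-3-fluorophenyl, gave a 4.1-fold lower number from compound 3 to compound 4 (0.61 log units; beyond the scatter), so the lower number seen on the core of compound 1 also appears on the core of compound 3. The change carried across both cores with much the same size, even though the altered carbon in compound 4 is ortho to a fluoro group, which the earlier pair lacks: the same change on two cores in this assay, a 3.6-fold lower number (0.56 log units; beyond the scatter) from compound 1 to compound 2 and a 4.1-fold lower number (0.61 log units; beyond the scatter) from compound 3 to compound 4, 1.1-fold (0.05 log units) apart, within the scatter of two such steps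

Two pairs on two cores do not show that the step would hold on any further core, and they give no reason why the number falls.

The compounds shown leave open whether chloro is special at this place or whether bromo, methyl, trifluoromethyl or a nitrile would give a similar step. Also open, going by these compounds, is what happens on the core of compound 3 when the remaining fluoro group gives way to hydrogen or to a second chloro.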